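The source may report more compounds than this note shows. Statements on the series, on what has been measured and on what is new or still open speak of the compounds shown alone.

Working notes on the series. Compound 3, `CCc1nc(-c2ccc(C)cc2OC)c(CC)nc1NC(CC)CC`, carries a methyl on the aromatic carbon where compound 1, `CCc1nc(-c2ccc(OC(F)(F)F)cc2OC)c(CC)nc1NC(CC)CC`, carries trifluoromethoxy. In an assay on IMR-32 cells for displacement of a labelled ligand from corticotropin-releasing factor receptor 1 (Homo sapiens), read by scintillation counting, with a stated time of 2 h (on this read-out higher numbers stand for weaker inhibition and lower numbers for stronger inhibition), compound 3 gives 23.7 nM, the highest number of the three measured compounds; compound 1 gives 7.2 nM, and compound 2, `CCc1nc(-c2ccc(OC)cc2C(F)(F)F)c(CC)nc1NC(CC)CC`, gives 4.4 nM. Both gaps from compound 3 lie beyond the scatter.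

Compound 4, `CCc1nc(-c2ccc(OC(C)C)cc2OC)c(CC)nc1NC(CC)CC`, differs from compound 3 by isopropoxy in place of methyl on an aromatic carbon. Going by the values given here, the one recorded single-point step bears on this change: a 3.3-fold higher number from compound 1 to compound 3 (0.52 log units; beyond the scatter). That step exchanged trifluoromethoxy for methyl and raised the number, so placing an alkoxy group back on that carbon is expected to move the number the other way. Isopropoxy is not trifluoromethoxy, and no measured step covers this exact exchange, so the expected movement is somewhat smaller than the reverse of that step, with wide uncertainty. For compound 4 the expected step in this assay is a 2.4-fold lower number from compound 3 to compound 4 (0.37 log units; beyond the scatter). Compound 4 is therefore estimated at 10 nM, with a range of 3.5 nM to 28 nM.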

Compound 4, inhibition constant: 4.2 nM
For compound 4 the middle estimate is 2.4-fold (0.38 log units) above the measured one; the range from low to high includes it.
By their numbers in this assay, from the lowest: compounds 4, 2 and 1 (each within the scatter of the next); then compound 3.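

In this assay the step of a 5.6-fold lower number from compound 3 to compound 4 (0.75 log units; beyond the scatter) gives this aromatic carbon a second oxygen-linked group, and both isopropoxy and trifluoromethoxy give lower numbers than methyl. The step of a 1.7-fold lower number from compound 1 to compound 4 (0.23 log units; within the scatter) shows that isopropyl and trifluoromethyl on that oxygen cannot be told apart here. Among compounds 1, 3 and 4, the position therefore accepts isopropoxy, with 4 heavy atoms against 1 for methyl, with no loss beyond the scatter relative to trifluoromethoxy. No measurement is available that explains these differences.

On these data alone, it remains open whether the oxygen itself matters, which an isopropyl attached directly to the aromatic carbon would test. Also open, as far as these compounds go, is whether a longer chain on the oxygen, or an amine on the same carbon, would keep the number at this level.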